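The source may hold more compounds than are shown below. What is called first, only, known or untested is meant among the compounds shown, and "the series" means these compounds.

Three compounds were examined here: compound 1 `N#Cc1ccc(N2CCc3cc(-c4cncnc4)ccc32)cc1C(F)(F)F`, compound 2 `CCN(c1ccc(C#N)c(Cl)c1)c1cc(-n2cnc3ccccc32)ccc1C` and compound 3 `N#Cc1ccc(N2CCCc3c(-c4ccncc4)cccc32)cc1C(F)(F)F`. In a functional assay on CWR22R cells (Homo sapiens) for antiproliferative activity, read by CCK-8 assay, with a stated time of 6 days (on this read-out higher numbers stand for weaker inhibition and lower numbers for stronger inhibition), compound 2 gives 3040 nM, while compound 3 gives 15000 nM. For compound 1 the outcome in this assay stands as "not determined" (no result reported). Within the data shown here, compound 2 therefore holds the lower of the two known numbers, with compound 3 the nearest entry at a clearly higher value, a gap beyond the usual scatter.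

The next compound, compound 4 `CCN(c1ccc(C#N)c(Cl)c1)c1cc(-n2ccnc2)ccc1C`, has not yet been tested in this assay. It differs from compound 2 in one place: 1H-imidazol-1-yl in place of 1H-benzimidazol-1-yl on an aromatic carbon. The group that leaves includes a six-membered aromatic ring of carbon only; the group that enters keeps the five-membered aromatic ring with 2 hetero atoms and nothing more.

Among the measured compounds shown here, no step between measured compounds shows what this kind of change does, so only a cautious expectation is possible. Removing part of an aromatic group is expected to weaken inhibition somewhat, by an amount of a 2.3-fold higher number from compound 2 to compound 4 (0.36 log units; beyond the scatter), with a fair chance that it falls within the scatter. Compound 4 is thus expected to give 7000 nM, in a range from 2000 nM to 25000 nM.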

Compound 4, half-maximal inhibitory concentration: > 30000 nM
Compound 4 gave a limit, no number; the forecaster's own chance of this, stated with the estimate: 10%; at least 4.2-fold (0.63 log units) between middle value and limit.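

On this aromatic carbon, para to a methyl group, replacing 1H-benzimidazol-1-yl with 1H-imidazol-1-yl in this assay gives an at least 9.8-fold higher number from compound 2 to compound 4 (0.99 log units; beyond the scatter), so the six-membered aromatic ring of carbon only in the departing group clearly counts for this read-out. The reading for compound 4 is a limit of the assay and not a number: the limit of > 30000 nM in this assay, at which 1 of the 4 values shown sits. Among these compounds, the earlier compounds offered no step of this kind, so they could not show that this place responds so strongly to losing that ring, and the true size of the step remains unknown.

The compounds shown do not tell why the ring matters. They also leave open how this carbon would respond to other groups, such as 1H-indol-1-yl, which keeps both rings but has one nitrogen fewer, a phenyl ring or a simple amine.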